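Pyridinyl for Cyclohexyl in a Cyanoguanidine Series

A few compounds are considered here, and "the series" means these few. Any claim that something is new, unique, unknown or untested is made for them only; others in the source may bear on it.

compound 1 `N#C/N=C(/NCCCc1c[nH]cn1)NCCCC1CCCCC1` — < 5; < 5 (2 entries)
compound 2 `N#C/N=C(/NCCCc1c[nH]cn1)NCCSc1ccccc1` — < 5
compound 3 `N#C/N=C(/NCCCCc1c[nH]cn1)NCCCC1CCCCC1` — < 5

The three measured compounds were tested in an in vitro functional assay on Sf9 cells for antagonist activity at histamine H2 receptor (Homo sapiens); on this read-out lower numbers stand for lower potency and higher numbers for higher potency (the scale is a negative logarithm). Compound 1 gives < 5; < 5 (2 entries), both entries being limits of the assay rather than numbers. Compound 2 gives < 5, also a limit. Compound 3 stands at < 5, a limit of the assay as well, so its place among the measured compounds is simply (the limit of < 5 in this assay, at which 2 of the 3 values shown sit). Going by the values given here, no pair of measured compounds differs in a single place, so no measured step is available to gauge how large a change one substitution brings.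

Compound 4 `N#C/N=C(/NCCCCc1c[nH]cn1)NCCCc1cccnc1` differs from compound 3 by pyridin-3-yl in place of cyclohexyl on a saturated chain carbon, three bonds along the chain from an amine nitrogen. The step is expected to be a number at least 0.30 log units higher from compound 3 to compound 4 (that floor lies within the scatter), a modest rise that may not clear the scatter. Compound 4 is estimated at 5.3, within a range from 4.5 to 6.1.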

Compound 4, negative logarithm of the antagonist equilibrium constant: 5.92
Estimate against measurement, compound 4: 0.62 log units below; measured number inside the range.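

In this assay, pyridin-3-yl in place of cyclohexyl on a saturated chain carbon, three bonds along the chain from an amine nitrogen, gives a number at least 0.92 log units higher from compound 3 to compound 4 (beyond the scatter). The earlier compounds shown here offered no measured step, and this one shows that a single change at this position can reach beyond the scatter. Compound 4 alone among those shown carries a number, while the others stand at a limit of the assay: the limit of < 5 in this assay, at which 2 of the 4 values shown sit.

From the compounds shown here alone, the full size of the step stays open. The compounds shown also do not tell whether pyridin-4-yl or phenyl at this place would serve as well.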